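Phenylpiperazine in Place of Propyl on a Dihydropyridine

The source may report more compounds than this note shows. Statements on the series, on what has been measured and on what is new or still open speak of the compounds shown alone.

Compound 1 `CCCCC1=C(C(=O)OCC)C(c2cccc([N+](=O)[O-])c2)C(C(=O)OCC)=C(C)N1` gives 20 nM
Compound 2 `CCOC(=O)C1=C(C)NC(COC)=C(C(=O)OC)C1c1cccc([N+](=O)[O-])c1` gives 14 nM

Two compounds were measured in a functional assay on HEK293 cells for antagonist activity at Voltage-dependent L-type calcium channel subunit alpha-1C (Oryctolagus cuniculus), read by FLIPR; on this read-out higher numbers stand for weaker inhibition and lower numbers for stronger inhibition. Compound 1 shows the higher of the two numbers, with 20 nM; compound 2 stands at 14 nM. The gap between them lies within the scatter of repeated measurements, so the two cannot be told apart on this read-out.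

Compound 3 `CCOC(=O)C1=C(C)NC(CN2CCN(c3ccccc3)CC2)=C(C(=O)OCC)C1c1cccc([N+](=O)[O-])c1` has not yet been measured. It differs from compound 1 in one place: 4-phenylpiperazin-1-yl in place of propyl on a saturated chain carbon bound to a double-bonded ring carbon. Among the measured compounds shown here, no pair of measured compounds shares this change, so nothing measured here tells how large a step it brings.

The account therefore rests on compound 1 alone, with its value of 20 nM as the starting point. The step from compound 1 to compound 3 is expected to be modest, in the direction of stronger inhibition, a 2.0-fold lower number from compound 1 to compound 3 (0.30 log units; within the scatter). On that basis compound 3 is estimated at 10 nM in this assay, within a range from 2 nM to 50 nM.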

Compound 3, half-maximal inhibitory concentration: 630 nM
Beside the measured number, compound 3's estimate is 63-fold (1.80 log units) below it; the measured number lies above the stated range.
By their numbers in this assay, from the lowest: compounds 2 and 1 (each within the scatter of the next); then compound 3.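

In this assay, the saturated chain carbon bound to a double-bonded ring carbon turns out not to accept every group equally: 4-phenylpiperazin-1-yl in place of propyl at this place gives a 32-fold higher number from compound 1 to compound 3 (1.50 log units; beyond the scatter), a clear loss of inhibition. The earlier compounds shown here could not show this, since compound 1 and compound 2 stand within the scatter of each other and differ in more than one place, so they offered no step at this position. Nothing available bears on why this change has so large an effect.

Among the compounds shown here, the single step replaces propyl with a group that holds both a piperazine ring and a phenyl ring, so it leaves open which part goes with the weaker inhibition. A piperazine without the phenyl, a piperidine, or a plain carbon chain longer than propyl on the same carbon would begin to separate these parts, and a single change on the core of compound 1 cannot say whether the same step would hold on other esters or aryl groups.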